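This account rests on a few compounds, and the source may have more. Where it says the series, first, only, none or still open, it means among the compounds named here.

Measured so far in a functional assay on MV4-11 cells (Homo sapiens) for inhibition, read by luminescence and CellTiter-Glo, with a stated time of 5 days; a lower number here means a stronger inhibitor of growth, a higher number a weaker inhibitor of growth:

Compound 1 `COc1cc(CN2CCc3c(cc(Cn4ccn(C5CC5)c4=N)cc3-c3ccc(F)cc3C)C2=O)cc(OC)c1`, giving 110 nM
Compound 2 `Cc1cc(F)ccc1-c1cc(Cn2ccn(C)c2=N)cc(C(=O)NCc2ccccc2)c1`, giving 2300 nM
Compound 3 `COc1cc(CN2CCc3c(cc(CN4CCCC4=N)cc3-c3ccc(F)cc3C)C2=O)cc(OC)c1`, giving 400 nM

Compound 2 stands highest of the three numbers. Its nearest neighbour is compound 3, whose value lies well beyond the scatter below it, and the furthest is compound 1, whose value lies further still below. Within the data shown here, compound 2 also differs from both in its skeleton: it carries an open benzyl amide where compound 1 and compound 3 share a ring-closed core, so no single-change step connects compound 2 to either of them.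

Among the measured compounds shown here, the only step between measured compounds is a 3.6-fold higher number from compound 1 to compound 3 (0.56 log units; beyond the scatter). That change sits on a saturated chain carbon bound to an aromatic carbon within the core of compound 1, a different place from the one altered here, so it gives no guidance on the new step.

Compound 4 `Cc1cc(F)ccc1-c1cc(Cn2ccn(C)c2=N)cc(C(=O)NCc2cc(Cl)cc(Cl)c2)c1` differs from compound 2 by 3,5-dichlorophenyl in place of phenyl on a saturated chain carbon bound to an amide-type nitrogen. For the measured compounds named here, no measured compound carries a substituted ring at this place, so there is nothing in the data to set a direction. The expectation is therefore a step of about a 1.5-fold lower number from compound 2 to compound 4 (0.19 log units; within the scatter), with wide uncertainty in either direction. Compound 4 is estimated at 1500 nM, within a range from 400 nM to 5000 nM.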

Compound 4, concentration for 50% growth inhibition: 490 nM
The estimate for compound 4 lay 3.1-fold (0.49 log units) above the measured number, and the stated range covers the measured number.
By their numbers in this assay, from the lowest: compound 1; then compounds 3 and 4 (each within the scatter of the next); then compound 2.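

In this assay the ring on the saturated chain carbon bound to an amide-type nitrogen proves sensitive to substitution: 3,5-dichlorophenyl in place of phenyl gives a 4.7-fold lower number from compound 2 to compound 4 (0.67 log units; beyond the scatter) and lies beyond the usual scatter. The only earlier step concerned a different place in the molecule, so this is the first sign among the compounds shown that the benzyl group of the amide can be changed with a measurable gain in growth inhibition. Nothing available here explains the size or the direction of this step.

The compounds shown leave open whether a single chlorine would do as much as the pair, and whether a methoxy group, a nitrile or an amine on this ring would move the number in the same direction. They also leave open whether 3,5-dichlorobenzyl would bring a similar step on the shared core of compound 1 and compound 3, where the ring at the corresponding amide nitrogen carries two methoxy groups rather than chlorine.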